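Chloro to bromo on the benzyl ether: second instance

The source may hold more compounds than are shown below. What is called first, only, known or untested is meant among the compounds shown, and "the series" means these compounds.

Compound 1 `O=c1c(OCc2cccc(Cl)c2)c(-c2ccccc2)oc2cc(O)cc(O)c12` serves as the reference of this small set. In an ADME assay on Huh-5-2 cells (Homo sapiens) for cytotoxicity, read by WST assay, with a stated time of 3 days (a higher number here means that more compound is tolerated, a lower number that less compound is tolerated), compound 1 gives 46000 nM. Compound 2 `O=c1c(OCc2cccc(Br)c2)c(-c2ccccc2)oc2cc(O)cc(O)c12` differs from it by bromo in place of chloro on an aromatic carbon, and in this assay compound 2 gives 15000 nM; the step is a 3.1-fold lower number from compound 1 to compound 2 (0.49 log units; beyond the scatter). Compound 3 `O=c1c(OCc2ccc(Cl)cc2)c(-c2ccccc2)oc2cc(O)cc(O)c12` carries the same atoms as compound 1, joined differently: 4-chlorophenyl in place of 3-chlorophenyl on a saturated chain carbon bound to an oxygen on an aromatic ring. In this assay compound 3 gives 36000 nM, and the step from compound 1 is a 1.3-fold lower number from compound 1 to compound 3 (0.11 log units; within the scatter), so the two cannot be ordered. From compound 2 to compound 3 the step is a 2.4-fold higher number from compound 2 to compound 3 (0.38 log units; beyond the scatter).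

Compound 4 `O=c1c(OCc2ccc(Br)cc2)c(-c2ccccc2)oc2cc(O)cc(O)c12` has not been measured. It differs from compound 3 by bromo in place of chloro on an aromatic carbon. Within the data shown here, this is the same kind of change as the one from compound 1 to compound 2, but not the same: there the bromo sits meta to a large group, here it sits para to a large group. The difference between the two cores is given by 4-chlorophenyl in place of 3-chlorophenyl on a saturated chain carbon bound to an oxygen on an aromatic ring, which on its own moved the number only within the scatter.

With one earlier instance only, the expectation for compound 4 rests on that single step a 3.1-fold lower number from compound 1 to compound 2 (0.49 log units; beyond the scatter) applied to compound 3 with 36000 nM, and is estimated as a 2.8-fold lower number from compound 3 to compound 4 (0.44 log units; beyond the scatter). Among the measured compounds shown here, compound 4 is therefore expected to give about 13000 nM in this assay, within a range of 6000 nM to 30000 nM, the width reflecting that the para position has no measured precedent here.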

Compound 4, half-maximal cytotoxic concentration: 2000 nM
Compound 4: middle estimate off by 6.5-fold (0.81 log units), on the high side, outside the stated range (below it).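

The change from chloro to bromo does not carry over from one core to the other as a fixed step in this assay, although the number falls on both cores: the same change on two cores in this assay, a 3.1-fold lower number (0.49 log units; beyond the scatter) from compound 1 to compound 2 and an 18-fold lower number (1.26 log units; beyond the scatter) from compound 3 to compound 4, 5.9-fold (0.77 log units) apart, beyond the scatter of two such steps With bromo on both compounds, the move from 3-bromophenyl to 4-bromophenyl gives a 7.5-fold lower number from compound 2 to compound 4 (0.88 log units; beyond the scatter), whereas the matching chloro pair differs only within the scatter, and the two changes taken together give a 23-fold lower number from compound 1 to compound 4 (1.36 log units; beyond the scatter), so in these four compounds the effect of the halogen depends on where it sits. This rests on just two pairs, so it shows that a step measured on the core of compound 1 gave the direction but not the size of an 18-fold lower number from compound 3 to compound 4 (1.26 log units; beyond the scatter); it does not show why the steps differ, nor that the same dependence holds beyond these compounds.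

The compounds shown leave open whether fluoro or iodo in the same two places would follow the chloro or the bromo compounds. They also leave open whether a non-halogen group on the benzyl ring, such as an amine or a carboxylic acid, would show any such dependence on position.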